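Ester Chain Unsaturation and Cell Toxicity in Four Amides

The source may hold more compounds than are shown below. What is called first, only, known or untested is meant among the compounds shown, and "the series" means these compounds.

Compound 1 `COC(=O)/C=C/CNC(=O)c1cccc2c1NC(C)(C)C=C2C` gives in an ADME assay on HeLa cells (Homo sapiens) for cytotoxicity (on this read-out higher numbers stand for lower toxicity in this test and lower numbers for higher toxicity in this test), only a limit, > 30000 nM.
Compound 2 `COC(=O)CCCNC(=O)c1cccc2c1NC(C)(C)C=C2C` gives in this assay only a limit, > 30000 nM.
Compound 3 `COC(=O)CCCNC(=O)c1cccc2c1NC(C)(C)C[C@H]2C` gives in this assay only a limit, > 30000 nM.

All three measured compounds sit at the same limit, (the limit of > 30000 nM in this assay, at which 3 of the 3 values shown sit), so none of them showed toxicity within the tested range. The change from compound 2 to compound 1 is 2-(methoxycarbonyl)ethenyl in place of 2-(methoxycarbonyl)ethyl on a saturated chain carbon bound to an amide-type nitrogen, and its size is a step that the two limits leave unreadable from compound 2 to compound 1. Compound 4 `COC(=O)/C=C/CNC(=O)c1cccc2c1NC(C)(C)C[C@H]2C` carries the same change on the core of compound 3: 2-(methoxycarbonyl)ethenyl in place of 2-(methoxycarbonyl)ethyl on a saturated chain carbon bound to an amide-type nitrogen. How the core of compound 3 differs from that of compound 2 is not broken down here.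

Since the step from compound 2 to compound 1 could not be read and every value is a limit, there is no measured effect of this change to carry over. Compound 4 is therefore expected to sit at the same limit, with an expected step that the limit leaves unreadable from compound 3 to compound 4, and its value in this assay is estimated at 60000 nM, between 30000 nM and 200000 nM, most likely again only as a limit.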

Compound 4, half-maximal cytotoxic concentration: > 30000 nM
Compound 4: a limit, no number; the forecaster's own chance of this, stated with the estimate: 85%; the middle value lies beyond the limit too.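

No size can be read for the change from compound 3 to compound 4, since both give only a limit in this assay and the same holds for compound 1 and compound 2: the limit of > 30000 nM in this assay, at which 4 of the 4 values shown sit.

The compounds shown leave open whether 2-(methoxycarbonyl)ethenyl and 2-(methoxycarbonyl)ethyl differ at all in toxicity, and at what concentration, if any, these four compounds would become toxic.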